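The source may hold more compounds than are shown below. What is called first, only, known or untested is meant among the compounds shown, and "the series" means these compounds.

Only two close relatives have been tested so far, and neither gives an exact number. In an ADME assay on HepG2 cells (Homo sapiens) for cytotoxicity, read by luminescence, with a stated time of 72 h (a higher number here means that more compound is needed for the effect, a lower number that less compound is needed), compound 1 `CCOC(=O)c1c(-c2cccc(OC)c2)[nH]c2cc(Cl)c(OC)cc2c1=O` gives > 21500 nM, which is a limit of the assay and not a number. Compound 2 `CCOC(=O)c1c(-c2cccc(-c3ccccc3)c2)[nH]c2cc(Cl)c(Cl)cc2c1=O` gives > 21500 nM, and this too is only a limit, so compound 2 has no exact position on the scale. Taken together, the results amount to the limit of > 21500 nM in this assay, at which 2 of the 2 values shown sit.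

Compound 3 `CCOC(=O)c1c(-c2cccc(OC)c2)[nH]c2cc(Cl)c(Cl)cc2c1=O` differs from compound 2 in one place, with methoxy in place of phenyl on an aromatic carbon, meta to a large group: methoxy in place of phenyl on an aromatic carbon. Going by the values given here, no measured pair shows what this exchange does in this assay, so the expectation rests on the two limits alone. With both tested compounds giving only a limit, no step beyond the usual scatter is expected, and the most likely report for compound 3 is another limit. The estimate corresponds to an expected step of a number no higher from compound 2 to compound 3 (the limit leaves the size open). For compound 3 the estimated value is 21500 nM, with an expected range from 10000 nM to 43000 nM.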

Compound 3, half-maximal effective concentration: > 21500 nM
Compound 3: only a limit was reported; the forecaster's own chance of this, stated with the estimate: 80%; the middle value lies on the limit itself.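

The steps from compound 2 to compound 3 and from compound 1 to compound 3 cannot be read: in this assay all three compounds give only a limit. These compounds leave open where each would sit on the scale, and whether methoxy in place of phenyl, or chloro in place of methoxy, changes the concentration needed for the effect.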